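The source may hold more compounds than are shown below. What is called first, only, known or untested is meant among the compounds shown, and "the series" means these compounds.

Measured so far:
compound 1, `CCc1cc(C(C)=O)c(O)cc1OCCCCCCCC(C)(C)C#N`, 6%
compound 2, `CCc1cc(C(C)=O)c(O)cc1OCCCCCCC(C)(C)c1nnn[nH]1`, 13%
compound 3, `C=CCc1cc(C(C)=O)c(O)cc1OCc1cccc(C#N)c1`, 25%

In an assay on isolated protein for binding affinity to leukotriene B4 receptor (Homo sapiens), tested at 0.1 uM (a lower number here means less inhibition, a higher number more inhibition at the concentration tested (going by the name of the read-out)), compound 3 stands highest of the three numbers, beyond the scatter above compound 2 and compound 1. Compound 4, `CCc1cc(C(C)=O)c(O)cc1OCc1cccc(C#N)c1`, differs from compound 3 in one place: methyl in place of vinyl on a saturated chain carbon bound to an aromatic carbon. Cut one bond further out, the same difference reads allyl to ethyl, so compound 4 carries on its core the ethyl that compound 1 and compound 2 also carry, while the rest of compound 4 matches compound 3.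

Among the compounds with values here, no measured step touches this position. Within the data shown here, the only step measured, a number 7 percentage points higher from compound 1 to compound 2 (within the scatter), changes the far end of a chain and stays within the scatter, so it tells nothing about swapping vinyl for methyl. Among the measured compounds shown here, with no step bearing on it, the expectation for compound 4 in this assay is a small shift at most, none beyond the scatter, estimated as a number 3 percentage points lower from compound 3 to compound 4 (within the scatter). Compound 4 is therefore expected to give about 22%, within a range from 10% to 34%.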

Compound 4, a percentage reported as inhibition, at one concentration (the size of the read-out at that concentration, not a potency): 18%
Compound 4: middle estimate off by 4 percentage points, on the high side; low and high end bracket the measured number.
By their numbers in this assay, from the lowest: compounds 1, 2, 4 and 3 (each within the scatter of the next, the first and the last beyond it).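

In this assay, within the data shown here, the step of a number 7 percentage points lower from compound 3 to compound 4 (within the scatter) is the first measured change at this position, where methyl replaces vinyl on a saturated chain carbon bound to an aromatic carbon; the same difference, cut one bond further out, reads allyl to ethyl. Removing the double bond outside the aromatic rings therefore leaves the read-out within the usual scatter, so compound 3 and compound 4 cannot be told apart at this single concentration. Nothing available gives a reason for this result.

From the compounds shown here alone, whether a longer chain such as butyl, or a chain ending in an amine or a carboxylic acid, would shift the read-out at this position remains open. Also open, going by these compounds, is whether allyl and ethyl would compare in the same way with the long side chain of compound 1 on the oxygen.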